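Amide nitrogen substituent series: extending the alkyl chain

This account rests on a few compounds, and the source may have more. Where it says the series, first, only, none or still open, it means among the compounds named here.

Measured compounds:
compound 1 `NC(=O)CC[C@H](NS(=O)(=O)c1ccc([N+](=O)[O-])cc1)C(=O)O` — 7000 nM
compound 2 `CNC(=O)CC[C@H](NS(=O)(=O)c1ccc([N+](=O)[O-])cc1)C(=O)O` — 7500 nM
compound 3 `CCCCNC(=O)CC[C@H](NS(=O)(=O)c1ccc([N+](=O)[O-])cc1)C(=O)O` — 6360 nM

All three share a core that differs only at the amide-type nitrogen. In an assay for inhibition of matrix metalloproteinase-9 (Homo sapiens), with stated times of 1 h, 1 min and 30 min (on this read-out higher numbers stand for weaker inhibition and lower numbers for stronger inhibition), compound 3 gives the lowest of the three numbers, but its steps to both neighbours are within the scatter, so no order among the three can be read from these values: a 1.1-fold lower number from compound 1 to compound 3 (0.04 log units; within the scatter) and a 1.2-fold lower number from compound 2 to compound 3 (0.07 log units; within the scatter).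

Compound 4 `CCCCCNC(=O)CC[C@H](NS(=O)(=O)c1ccc([N+](=O)[O-])cc1)C(=O)O` is not yet measured. Relative to compound 3 the change is methyl in place of hydrogen on a saturated chain carbon, four bonds along the chain from an amide-type nitrogen, which is one more step in the same chain lengthening that the measured steps already trace. Those steps bear directly on it: a 1.1-fold higher number from compound 1 to compound 2 (0.03 log units; within the scatter), then a 1.2-fold lower number from compound 2 to compound 3 (0.07 log units; within the scatter). Putting hydrogen, methyl or butyl on that nitrogen left this assay essentially unmoved. Nothing in the series suggests that one further methyl on the chain should behave otherwise.

For compound 4, therefore, the expected step is a 1.0-fold lower number from compound 3 to compound 4 (0.01 log units; within the scatter), that is, no step beyond the scatter in either direction. The estimate for compound 4 in this assay is 6200 nM, with a range from 3100 nM to 12400 nM.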

Compound 4, half-maximal inhibitory concentration: 6800 nM
Estimate against measurement, compound 4: 1.1-fold (0.04 log units) below, within the range that was stated.
By their numbers in this assay, from the lowest: compounds 3, 4, 1 and 2 (each within the scatter of the next).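

In this assay the methyl in place of hydrogen on a saturated chain carbon, four bonds along the chain from an amide-type nitrogen, gives a step within the scatter (a 1.1-fold higher number from compound 3 to compound 4 (0.03 log units; within the scatter)), so this further chain carbon adds no measurable change to the butyl compound. Pentyl also stays level with the shorter members (a 1.1-fold lower number from compound 2 to compound 4 (0.04 log units; within the scatter); a 1.0-fold lower number from compound 1 to compound 4 (0.01 log units; within the scatter)), which extends the flat pattern to hydrogen, methyl, butyl and pentyl on that nitrogen, with none of these four compounds going against it. No measured evidence at hand speaks to why these numbers lie so close together.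

The compounds shown leave open whether a longer chain such as octyl or decyl, or a branched group such as isopropyl or tert-butyl, would stay equally level in this assay. They also leave open whether a phenyl or benzyl group on that nitrogen, or an amine or a carboxylic acid at the end of the chain, would move the number beyond the scatter.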